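This account rests on a few compounds, and the source may have more. Where it says the series, first, only, none or still open, it means among the compounds named here.

In an in vitro ADME assay on microsomes from liver (Rattus norvegicus) for metabolic stability, read by LC-MS, using NADPH, tested at 1 uM (on this read-out lower numbers stand for a shorter-lived compound and higher numbers for a longer-lived compound), three compounds have been measured. Compound 1 `CCN1C(=O)CN(Cc2ccc(-c3cccc(CN4CCCCC4)n3)cc2)C1=O`, which carries ethyl, gives 0.95 h. Compound 2 `CCN1C(=O)CN(Cc2ccc(-c3ccc(F)c(CN4CCCCC4)n3)cc2)C1=O`, which adds fluoro on an aromatic carbon, gives 0.517 h. Compound 3 `O=C1CN(Cc2ccc(-c3cccc(CN4CCCCC4)n3)cc2)C(=O)N1C1CC1`, which carries cyclopropyl, gives 1.42 h. That number lies within the usual scatter of compound 1 and beyond the scatter of compound 2.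

Compound 4 `CC(C)N1C(=O)CN(Cc2ccc(-c3cccc(CN4CCCCC4)n3)cc2)C1=O` differs from compound 3 in one place, with isopropyl in place of cyclopropyl on an amide-type nitrogen in a ring. The most relevant evidence is the change at that same nitrogen, a 1.5-fold higher number from compound 1 to compound 3 (0.17 log units; within the scatter). The fluoro change, a 1.8-fold lower number from compound 1 to compound 2 (0.26 log units; within the scatter), lies elsewhere and says little about this swap. Among the measured compounds shown here, no measured compound carries isopropyl, so the evidence is indirect. Because a 1.5-fold higher number from compound 1 to compound 3 (0.17 log units; within the scatter) stayed within the scatter, no step beyond the scatter is expected here. The expected step is a 1.3-fold lower number from compound 3 to compound 4 (0.11 log units; within the scatter), which is small and slightly downward. Compound 4 is estimated at 1.1 h, with an expected range from 0.6 h to 2 h.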

Compound 4, half-life in the Rattus norvegicus assay: 0.75 h
Compound 4: middle estimate off by 1.5-fold (0.17 log units), on the high side; the measured number falls inside the stated range.
By their numbers in the Rattus norvegicus assay, from the lowest: compounds 2, 4, 1 and 3 (each within the scatter of the next, the first and the last beyond it).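

In the Rattus norvegicus assay, the ring of cyclopropyl opens to isopropyl with a 1.9-fold lower number from compound 3 to compound 4 (0.28 log units; within the scatter), and the step from ethyl to isopropyl is a 1.3-fold lower number from compound 1 to compound 4 (0.10 log units; within the scatter). With the earlier step from ethyl to cyclopropyl also within the scatter, the three groups seen on this amide-type nitrogen cannot be told apart on half-life. The swap keeps the same count of heavy atoms, yet it does separate compound 3 and compound 4 on lipophilicity in a physicochemical assay for lipophilicity (on this read-out lower numbers stand for lower lipophilicity and higher numbers for higher lipophilicity), a difference that comes without a half-life step beyond the scatter in this one pair: the measured distribution coefficient of compound 3, 1.6, and of compound 4, 2.2, a number 0.60 log units higher (beyond the scatter) In the physicochemical assay compound 3 gives 1.6 and compound 4 gives 2.2.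

Still open, as far as these compounds go, is whether a longer chain such as n-butyl, or a chain carrying an ether oxygen such as methoxyethyl, on this nitrogen would move the half-life beyond the scatter. Also open, from the compounds shown here alone, is whether the isopropyl result would hold with fluoro on the aromatic carbon of compound 2.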